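The source may report more compounds than this note shows. Statements on the series, on what has been measured and on what is new or still open speak of the compounds shown alone.

In a functional assay on BXPC-3 cells (Homo sapiens) for antiproliferative activity, read by MTT assay, with a stated time of 24 h (a lower number here means a stronger inhibitor, a higher number a weaker inhibitor), compound 1 (`CCn1c(C(=O)N[C@H](C)C(=O)OC)ccc1C(CC)(CC)c1ccc(OCS(=O)(=O)c2ccccc2)c(C)c1`) gives > 50000 nM as a limit, not a number. Compound 2 (`CCn1c(C(=O)NC2(C(=O)O)CC2)ccc1C(CC)(CC)c1ccc(OCS(=O)(=O)c2ccccc2)c(C)c1`) gives > 50000 nM as a limit too. For the measured compounds named here, both values sit at the same limit (the limit of > 50000 nM in this assay, at which 2 of the 2 values shown sit), and the only measured step (a step that the two limits leave unreadable from compound 1 to compound 2) has no size to carry forward. Compound 3 (`CCn1c(C(=O)N[C@H](C(=O)O)C(C)C)ccc1C(CC)(CC)c1ccc(OCS(=O)(=O)c2ccccc2)c(C)c1`) differs from compound 2 (1-carboxy-2-methylpropyl in place of 1-carboxycyclopropyl on an amide-type nitrogen), with 1-carboxy-2-methylpropyl in place of 1-carboxycyclopropyl on an amide-type nitrogen. In this assay no step beyond the scatter is therefore expected (a number no higher from compound 2 to compound 3 (the limit leaves the size open)). The estimate for compound 3 is 50000 nM (expected range 20000 nM to 100000 nM), and another limit is the likeliest report.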

Compound 3, half-maximal inhibitory concentration: 16200 nM
For compound 3 the middle estimate is 3.1-fold (0.49 log units) above the measured one; the whole stated range lies above it.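

In this assay, the group on the amide-type nitrogen now visibly moves the read-out: 1-carboxy-2-methylpropyl gives an at least 3.0-fold lower number from compound 2 to compound 3 (0.48 log units; beyond the scatter) and also an at least 3.0-fold lower number from compound 1 to compound 3 (0.48 log units; beyond the scatter). Both steps are lower bounds, and the step from compound 1 to compound 2 cannot be read. For the compounds shown here, compound 3 is the only compound here with a number, and the other two stay at a limit: the limit of > 50000 nM in this assay, at which 2 of the 3 values shown sit.

Going by these compounds, the full size of both steps stays open. So does what an amine or a longer chain on that nitrogen would give in place of 1-carboxy-2-methylpropyl.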